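The compounds below may be only part of what the source reports. "The series", "measured", "known", "first", "only" and "open" are said of these compounds alone.

Working notes on the series. Among the compounds with values here, the shared core is that of compound 1 `COc1cc(-c2nc3ccccc3s2)ccc1OCC(=O)NNC(=O)CCl`, which in a functional assay on MCF7 cells (Homo sapiens) for inhibition, read by MTT assay, with a stated time of 3 days (a higher number here means a weaker inhibitor, a lower number a stronger inhibitor), gives 780 nM, the lowest of the three numbers measured so far. Compound 2 `CCOC(=O)[C@H](NCC(=O)NNC(=O)COc1ccc(-c2nc3ccccc3s2)cc1OC)[C@@H](C)CC` gives 2900 nM in this assay, and compound 3 `CCOC(=O)[C@H](CS)N(CC(=O)NNC(=O)COc1ccc(-c2nc3ccccc3s2)cc1OC)C(C)=O` gives 1890 nM. The two steps that replace the chloro group read a 3.7-fold higher number from compound 1 to compound 2 (0.57 log units; beyond the scatter) and a 2.4-fold higher number from compound 1 to compound 3 (0.38 log units; beyond the scatter): both move the number the same way, both beyond the scatter, both modest. The step of a 1.5-fold lower number from compound 2 to compound 3 (0.19 log units; within the scatter) stays within the scatter, so on these two compounds the two replacement groups are not separated.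

Compound 4 `CCOC(=O)[C@H](CCSC)NCC(=O)NNC(=O)COc1ccc(-c2nc3ccccc3s2)cc1OC` is the next step out from compound 1: (1-(ethoxycarbonyl)-3-(methylsulfanyl)propyl)amino in place of chloro on a saturated chain carbon bound to a carbonyl carbon. The entering group carries the ethoxycarbonyl and amino attachment also found in the group entering in compound 2, whose step a 3.7-fold higher number from compound 1 to compound 2 (0.57 log units; beyond the scatter) was modest, and in compound 3, whose step a 2.4-fold higher number from compound 1 to compound 3 (0.38 log units; beyond the scatter) was modest. A modest rise of the same kind is therefore expected for compound 4, a 3.1-fold higher number from compound 1 to compound 4 (0.49 log units; beyond the scatter), with the measurement still to come. Compound 4 is estimated at 2400 nM in this assay, in a range from 1200 nM to 5000 nM.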

Compound 4, half-maximal inhibitory concentration: 1760 nM
Estimate against measurement, compound 4: 1.4-fold (0.13 log units) above; the measured number falls inside the stated range.
By their numbers in this assay, from the lowest: compound 1; then compounds 4, 3 and 2 (each within the scatter of the next).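

In this assay, a third replacement of chloro on a saturated chain carbon bound to a carbonyl carbon moves the number the same way, a 2.3-fold higher number from compound 1 to compound 4 (0.35 log units; beyond the scatter), so the direction now holds for all three entering groups shown. The entering groups remain unseparated: with the amine nitrogen kept, 1-(ethoxycarbonyl)-3-(methylsulfanyl)propyl in place of 1-(ethoxycarbonyl)-2-methylbutyl gives a 1.6-fold lower number from compound 2 to compound 4 (0.22 log units; within the scatter), and the comparison with the acetylated group gives a 1.1-fold lower number from compound 3 to compound 4 (0.03 log units; within the scatter), both within the scatter. Nothing available explains these steps.

The compounds shown do not tell whether the rise follows the loss of chloro or the arrival of these larger groups. From the compounds shown here alone, whether a plain amine at this place, or a carboxylic acid in place of the ethoxycarbonyl, would stay close to compound 1 remains open.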